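This account rests on a few compounds, and the source may have more. Where it says the series, first, only, none or still open, it means among the compounds named here.

Measured compounds in a functional assay on HEK293 cells for agonist activity at Free fatty acid receptor 1 (Homo sapiens), read by fluorescence and calcium flux; a higher number here means that more compound is needed for the effect, a lower number that less compound is needed:
compound 1 `CC#CC(CC(=O)O)c1ccc(OCc2ccc(C(=O)N3CCN(c4ccccc4)CC3)s2)cc1` gives 72 nM;
compound 2 `CC#CC(CC(=O)O)c1ccc(OCc2ccc(C(=O)N3CCN(Cc4ccccc4)CC3)s2)cc1` gives 155 nM;
compound 3 `CC#CC(CC(=O)O)c1ccc(OCc2ccc(C(=O)N3CCN(c4ccncc4)CC3)s2)cc1` gives only a limit of the assay, > 5000 nM.

Compound 1 stands at the lowest of the two numbers in this assay. The nearest is compound 2, with a 2.2-fold higher number from compound 1 to compound 2 (0.33 log units; beyond the scatter), a modest step from benzyl in place of phenyl on the amine nitrogen in the ring. Compound 3 reaches the limit (the limit of > 5000 nM in this assay, at which 1 of the 3 values shown sits). The step of an at least 69-fold higher number from compound 1 to compound 3 (1.84 log units; beyond the scatter) is large, as is an at least 32-fold higher number from compound 2 to compound 3 (1.50 log units; beyond the scatter), so replacing the phenyl on that nitrogen by pyridin-4-yl removes measurable activity in this assay.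

Compound 4 `CC#CC(CC(=O)O)c1ccc(OCc2ccc(C(=O)N3CCN(c4cccc(F)c4)CC3)s2)cc1` differs from compound 1 by fluoro in place of hydrogen on an aromatic carbon; cut one bond further out, the change reads phenyl to 3-fluorophenyl. Within the data shown here, none of the measured steps bears directly on this change: each of them swaps the whole group on the nitrogen, whereas here the phenyl is kept and one hydrogen on it is exchanged. The large steps to compound 3 show that the group on the nitrogen matters, but give no guide to a single fluoro on a retained phenyl. The expectation is therefore a step of a 1.0-fold lower number from compound 1 to compound 4 (0.01 log units; within the scatter), none beyond the scatter. Compound 4 is estimated at 70 nM, within 35 nM to 140 nM.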

Compound 4, half-maximal effective concentration: 97 nM
Beside the measured number, compound 4's estimate is 1.4-fold (0.14 log units) below it, and the stated range covers the measured number.
By their numbers in this assay, from the lowest: compounds 1, 4 and 2 (each within the scatter of the next, the first and the last beyond it). At a limit, above all of these: compound 3.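

In this assay, a fluoro on an aromatic carbon of the retained phenyl, meta to a large group, is accepted without a change that can be told from scatter: a 1.3-fold higher number from compound 1 to compound 4 (0.13 log units; within the scatter). This place on the ring therefore takes at least this one small substituent, which the earlier swaps of the whole group on the amine nitrogen could not show. The other comparison within the scatter is a 1.6-fold lower number from compound 2 to compound 4 (0.20 log units; within the scatter), so 3-fluorophenyl and benzyl on that nitrogen are not separated in this assay. The large step of an at least 51-fold lower number from compound 3 to compound 4 (1.71 log units; beyond the scatter) rests on a limit and not on a number, and it shows that a substituted phenyl keeps the activity that pyridin-4-yl lacks: the limit of > 5000 nM in this assay, at which 1 of the 4 values shown sits.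

Still open, going by these compounds, is whether a bigger group in the same place, such as chloro, methoxy or trifluoromethyl, is accepted as the fluoro is, and whether fluoro elsewhere on the ring, as in 4-fluorophenyl, gives the same result. Also open, on these data alone, is whether the limit reached with pyridin-4-yl extends to pyridin-3-yl or pyridin-2-yl on the same amine nitrogen.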